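Adding a Second Chloro Atom Beside the First

The compounds below may be only part of what the source reports. "The series", "measured", "known", "first", "only" and "open" are said of these compounds alone.

Of the compounds shown here, two sharing a purine-like core have been tested in an assay on cells for displacement of a labelled ligand from adenosine receptor A3 (Homo sapiens), read by scintillation counting and radioligand binding, with a stated time of 180 min, tested at 10 uM; a higher number here means more inhibition at the concentration tested (going by the name of the read-out), a lower number less inhibition. Compound 1 `Cn1cnc2c(N3CCCCC3)nc(-c3ccccc3O)nc21` carries a piperidine and a phenol-type ring on the core, and in this assay compound 1 gives 20%. Compound 2 `CN1CCN(c2nc(-c3ccc(Cl)cc3)nc3[nH]cnc23)CC1` instead carries a methylpiperazine and a chlorophenyl ring. In this assay compound 2 reaches > 80%, which is a limit of the assay rather than an exact number, so compound 2 stands at the top of the range this assay can report; this is shown by the limit of > 80% in this assay, at which 1 of the 2 values shown sits. Going by the values given here, since only these two values are known and no two measured compounds differ in a single place, no measured step is available to calibrate how a small change alters the read-out.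

Compound 3 `CN1CCN(c2nc(-c3ccc(Cl)c(Cl)c3)nc3[nH]cnc23)CC1` is the next compound to be measured. It differs from compound 2 by one change (chloro in place of hydrogen on an aromatic carbon). Given that compound 2 sits at the limit, the expected step is a step that the limit leaves unreadable from compound 2 to compound 3, none beyond the scatter. Compound 3 is therefore estimated to show 88%, with a plausible range from 65% to 99%, and most likely again only the limit will be reported.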

Compound 3, a percentage reported as inhibition, at one concentration (the size of the read-out at that concentration, not a potency): > 80%
Compound 3: only a limit was reported; the forecaster's own chance of this, stated with the estimate: 65%; the middle value lies beyond the limit too.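

In this assay compound 3 gives > 80%, which is a limit of the assay and not an exact number. Compound 2 stands at that limit too, so no step can be read between compound 2 and compound 3: the limit of > 80% in this assay, at which 2 of the 3 values shown sit.

The compounds shown leave open whether going from 4-chlorophenyl to 3,4-dichlorophenyl changes the inhibition at all, and in which direction.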